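The compounds below may be only part of what the source reports. "The series", "measured", "known", "first", "only" and "open" are said of these compounds alone.

Working notes on the series.

Compound 2 `CCCCNc1nc(N)c2nc(O)n(Cc3ccccc3)c2n1` carries a butylamino group on the shared core and in a functional assay on the whole organism for activation, with Mus musculus as the target (a higher number here means that more compound is needed for the effect, a lower number that less compound is needed), compound 2 gives 0.1 mg/kg. Compound 1 `CCCCCNc1nc(N)c2nc(O)n(Cc3ccccc3)c2n1` differs from it by methyl in place of hydrogen on a saturated chain carbon, four bonds along the chain from a nitrogen on an aromatic ring, and in this assay compound 1 gives 0.3 mg/kg; the step is a 3.0-fold higher number from compound 2 to compound 1 (0.48 log units; beyond the scatter). Compound 3 `CCc1nc(N)c2nc(O)n(Cc3ccccc3)c2n1` replaces the chain on that aromatic carbon: the difference from compound 2 is ethyl in place of butylamino on an aromatic carbon. In this assay compound 3 gives 3 mg/kg, the highest minimum effective dose of the three, with a 10-fold higher number from compound 1 to compound 3 (1.00 log units; beyond the scatter) and a 30-fold higher number from compound 2 to compound 3 (1.48 log units; beyond the scatter).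

Compound 4 `CCCc1nc(N)c2nc(O)n(Cc3ccccc3)c2n1` is not yet measured. It differs from compound 3 by methyl in place of hydrogen on a saturated chain carbon, two bonds along the chain from an aromatic carbon. This is the same kind of change as the one from compound 2 to compound 1, the change counted as methyl in place of hydrogen on a saturated chain carbon, four bonds along the chain from a nitrogen on an aromatic ring; it occurs twice among these compounds, but the surroundings are not the same: in one case the methyl enters on a saturated chain carbon four bonds along the chain from a nitrogen on an aromatic ring, in the other on a saturated chain carbon two bonds along the chain from an aromatic carbon. The earlier step was a 3.0-fold higher number from compound 2 to compound 1 (0.48 log units; beyond the scatter). For the measured compounds named here, with only that one precedent, and on a differently placed chain, the expected step from compound 3 to compound 4 is a 1.3-fold higher number from compound 3 to compound 4 (0.12 log units; within the scatter), a flat to modestly higher number, resting on compound 1 at 0.3 mg/kg against compound 2. For compound 4 in this assay the estimate is 4 mg/kg, expected to fall between 1 mg/kg and 15 mg/kg.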

Compound 4, minimum effective dose: 3 mg/kg
The estimate for compound 4 lay 1.3-fold (0.12 log units) above the measured number; the measured number falls inside the stated range.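

In this assay, methyl in place of hydrogen on the ethyl chain of compound 3 gives no change at the digits printed from compound 3 to compound 4 (within the scatter), whereas the larger steps in this set come with propyl in place of an amino-linked chain: a 30-fold higher number from compound 2 to compound 4 (1.48 log units; beyond the scatter) and a 10-fold higher number from compound 1 to compound 4 (1.00 log units; beyond the scatter). The same methyl change therefore does not carry over at the same size from the butylamino chain to the ethyl chain: the same change on two cores in this assay, a 3.0-fold higher number (0.48 log units; beyond the scatter) from compound 2 to compound 1 and no change at the digits printed (within the scatter) from compound 3 to compound 4, 3.0-fold (0.48 log units) apart, beyond the scatter of two such steps. This shows that, in these two pairs, the step seen on one core does not predict the step on the other, but two pairs set no rule for the series, and they do not show what makes the steps differ.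

The compounds shown leave open whether a butyl or pentyl chain set directly on the aromatic carbon would stay level with compound 4 or move towards compound 2 and compound 1. They also leave open whether the gap to the amino-linked chains would hold for a butoxy chain in the same place, or for a butylamino chain ending in a carboxylic acid.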